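The compounds below may be only part of what the source reports. "The series", "measured", "known", "first", "only" and "open" are said of these compounds alone.

Measured compounds in an in vitro functional assay on CHO cells for antagonist activity at prostaglandin E2 receptor EP3 subtype (Mus musculus); on this read-out higher numbers stand for weaker inhibition and lower numbers for stronger inhibition:
compound 1 `O=C(O)/C=C/c1ccc(Cn2cccn2)cc1OCCc1ccc2ccccc2c1`, 73 nM
compound 2 `O=C(O)/C=C/c1ccc(Cc2ccccc2)cc1OCCc1ccc2ccccc2c1`, 400 nM

Compound 1 holds the lowest of the two numbers in this assay. Among the compounds with values here, the nearest is compound 2, which gives 400 nM; the single measured step is a 5.5-fold higher number from compound 1 to compound 2 (0.74 log units; beyond the scatter), a change at the (1H-pyrazol-1-yl)methyl group.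

Compound 3 `O=C(O)CCCc1ccc(Cn2cccn2)cc1OCCc1ccc2ccccc2c1` is not yet measured. It differs from compound 1 in one place: 3-carboxypropyl in place of 2-carboxyethenyl on an aromatic carbon. The place is an aromatic carbon of a six-membered aromatic ring of carbon only, ortho to a large group, para to a (1H-pyrazol-1-yl)methyl group.

Within the data shown here, no measured step touches the acid-bearing chain, so nothing anchors this change; the step from compound 1 to compound 2 concerns a different part of the core and gives no guidance here. The expectation therefore rests on the structural change alone, with a wide range. A modest rise in number beyond the scatter is expected, as a 3.4-fold higher number from compound 1 to compound 3 (0.53 log units; beyond the scatter). Compound 3 is thus expected to give 250 nM in this assay, within the range 60 nM to 1000 nM.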

Compound 3, half-maximal inhibitory concentration: 460 nM
Estimate against measurement, compound 3: 1.8-fold (0.26 log units) below, and the stated range covers the measured number.
By their numbers in this assay, from the lowest: compound 1; then compounds 2 and 3 (each within the scatter of the next).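

In this assay, the acid-bearing chain, on an aromatic carbon ortho to a large group and para to a (1H-pyrazol-1-yl)methyl group, is now a second place in the core of compound 1 where a change moves the number beyond the scatter: 3-carboxypropyl in place of 2-carboxyethenyl gives a 6.3-fold higher number from compound 1 to compound 3 (0.80 log units; beyond the scatter). This single step carries two differences at once, as the entering chain has 6 heavy atoms against 5 and 1 double bond outside aromatic rings against 2, while its hydrogen-bond donor and acceptor counts match those of the leaving chain, so the step cannot assign the rise to either difference. No measurement at hand accounts for the size of this step.

A 2-carboxyethyl chain on the same aromatic carbon would separate the loss of the double bond from the added chain length, and a 4-carboxybutyl chain would show whether further lengthening continues the trend. Also open, going by these compounds, is how a tetrazole in place of the carboxylic acid would read, and whether phenyl in place of 1H-pyrazol-1-yl would act in the same direction on the core of compound 3.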